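The compounds below may be only part of what the source reports. "The series", "measured", "known", "first", "only" and "open" are said of these compounds alone.

Measured compounds:
compound 1 `Cc1cc(Nc2cc(-c3ccccc3)[nH]n2)n2nc(SCc3cccc(Br)c3)nc2n1`: 5140 nM
compound 2 `Cc1cc(Nc2cc(-c3ccc(Cl)cc3)[nH]n2)n2nc(SCc3ccc(Br)cc3)nc2n1`: 3620 nM

Both compounds were tested in a functional assay on MCF7 cells (Homo sapiens) for inhibition, read by MTT assay, with a stated time of 72 h; a higher number here means a weaker inhibitor, a lower number a stronger inhibitor. Compound 1 gives 5140 nM, and compound 2 gives 3620 nM; the gap between them is within the usual scatter of such measurements, so neither can be ranked over the other. Compound 3 `C#CCSc1nc2nc(C)cc(Nc3cc(-c4ccccc4)[nH]n3)n2n1` has not yet been measured. Relative to compound 1 it carries one change: ethynyl in place of 3-bromophenyl on a saturated chain carbon bound to a sulfur. Among the measured compounds shown here, no measured pair shows this change, so its effect can only be estimated. Because compound 1 already gives 5140 nM, and with the 3-bromophenyl leaving and only an ethynyl entering, the expected direction is toward a weaker inhibitor, and the step of a 2.3-fold higher number from compound 1 to compound 3 (0.37 log units; beyond the scatter) is expected to lie beyond the scatter. Compound 3 is therefore estimated at 12000 nM, with a range from 4000 nM to 40000 nM.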

Compound 3, half-maximal inhibitory concentration: 21800 nM
The estimate for compound 3 lay 1.8-fold (0.26 log units) below the measured number; the range from low to high includes it.
By their numbers in this assay, from the lowest: compounds 2 and 1 (each within the scatter of the next); then compound 3.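

In this assay, among the compounds shown here, the exchange of 3-bromophenyl for ethynyl on a saturated chain carbon bound to a sulfur gives a 4.2-fold higher number from compound 1 to compound 3 (0.63 log units; beyond the scatter) and so offers the first single-place reading of this position. The earlier compounds shown here differ from each other in more than one place and could not show that this group matters; here, going from 3-bromobenzyl to propargyl yields a weaker inhibitor, by a step beyond the scatter. Nothing measured here explains this step.

The compounds shown leave open whether the ring or its bromine carries the difference, and how an unsubstituted phenyl, a longer alkyl chain or an amine would read at this place. They also leave open whether the same exchange would give a similar step on compound 2.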